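Swapping Cyclohexyl for Phenyl on the Ether Chain

The source may hold more compounds than are shown below. What is called first, only, known or untested is meant among the compounds shown, and "the series" means these compounds.

Measured compounds and their values:
compound 1, `O=c1c(Cc2coc3cccc(OCC4CCCCC4)c3c2=O)coc2ccccc12`: 3530 nM
compound 2, `Cc1ccc2c(=O)c(Cc3coc4cccc(OCC5CCCCC5)c4c3=O)coc2c1`: 2150 nM
compound 3, `O=c1c(Cc2coc3cccc(OCC4CCCCC4)c3c2=O)coc2cc(O)ccc12`: 3220 nM

In a functional assay on NUGC-3 cells (Homo sapiens) for antiproliferative activity, read by XTT assay (a lower number here means a stronger inhibitor, a higher number a weaker inhibitor), compound 1 gives the highest of the three numbers, though none of the three is separated from another beyond the scatter: a 1.6-fold lower number from compound 1 to compound 2 (0.22 log units; within the scatter) and a 1.1-fold lower number from compound 1 to compound 3 (0.04 log units; within the scatter) are both small, as is a 1.5-fold higher number from compound 2 to compound 3 (0.18 log units; within the scatter). Compound 4, `O=c1c(Cc2coc3cccc(OCc4ccccc4)c3c2=O)coc2ccccc12`, differs from compound 1 in one place: phenyl in place of cyclohexyl on a saturated chain carbon bound to an oxygen on an aromatic ring. For the measured compounds named here, no measured pair bears directly on this; the three measured steps all swapped a hydrogen on an aromatic carbon of the shared core for a methyl or a hydroxy, and each stayed within the scatter. Going by the values given here, the only guidance is that small changes to this core have so far moved this assay little, so for compound 4 no step beyond the scatter is expected, a 1.0-fold lower number from compound 1 to compound 4 (0.00 log units; within the scatter). Compound 4 is therefore estimated at 3500 nM, with a plausible range from 1500 nM to 8000 nM.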

Compound 4, half-maximal inhibitory concentration: 7220 nM
Beside the measured number, compound 4's estimate is 2.1-fold (0.31 log units) below it; the range from low to high includes it.
By their numbers in this assay, from the lowest: compounds 2, 3 and 1 (each within the scatter of the next); then compound 4.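

The earlier steps all changed an aromatic carbon of the shared core and stayed within the scatter, whereas this change to the ether chain is the only step shown that goes beyond it. In this assay, replacing cyclohexyl with phenyl gives a 2.0-fold higher number from compound 1 to compound 4 (0.31 log units; beyond the scatter), so the assay can tell these two rings apart at this position, although the step is modest and both rings have the same heavy-atom count and no hydrogen-bond donors or acceptors. The data offer no explanation for why the phenyl compound gives the higher number.

As far as these compounds go, whether a ring is needed on this chain remains open, and a plain butyl chain or a piperidine ring in its place would help to answer that. From the compounds shown here alone, it is also open whether methyl or hydroxy on the core would leave the benzyloxy compound as little changed as they left the cyclohexylmethoxy one.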